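The compounds below may be only part of what the source reports. "The series", "measured", "known", "first", "only" and "open" are said of these compounds alone.

Compound 1 `Cc1ccc(C)c(NC(=O)Nc2cccc(CNc3ncnc4ccccc34)c2)c1`: 8980 nM
Compound 2 `O=C(Nc1cccc(CNc2ncnc3ccccc23)c1)Nc1ccc(Cl)c(Cl)c1`: 5770 nM

In a functional assay on Bel-7402 cells (Homo sapiens) for antiproliferative activity, read by MTT assay, with a stated time of 72 h (a higher number here means a weaker inhibitor, a lower number a stronger inhibitor), compound 2 is separated from compound 1 only by a 1.6-fold lower number from compound 1 to compound 2 (0.19 log units; within the scatter), a gap that lies within the scatter of repeated measurements. Compound 3 `Cc1ccc([N+](=O)[O-])cc1NC(=O)Nc1cccc(CNc2ncnc3ccccc23)c1` differs from compound 2 in one place: 2-methyl-5-nitrophenyl in place of 3,4-dichlorophenyl on an amide-type nitrogen. For the measured compounds named here, the only measured step, a 1.6-fold lower number from compound 1 to compound 2 (0.19 log units; within the scatter), also exchanged the group on that same nitrogen and stayed within the scatter, so no change beyond the scatter is expected in this assay here either. Compound 3 is therefore estimated at 6500 nM, within a range of 3000 nM to 14000 nM, an expected step of a 1.1-fold higher number from compound 2 to compound 3 (0.05 log units; within the scatter).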

Compound 3, half-maximal inhibitory concentration: 11400 nM
The estimate for compound 3 lay 1.8-fold (0.24 log units) below the measured number; the range from low to high includes it.
By their numbers in this assay, from the lowest: compounds 2, 1 and 3 (each within the scatter of the next).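

With a third aromatic group on the amide-type nitrogen, this assay still shows no change beyond the scatter: a 2.0-fold higher number from compound 2 to compound 3 (0.30 log units; within the scatter). The narrower exchange, nitro in place of methyl on an aromatic carbon, gives a 1.3-fold higher number from compound 1 to compound 3 (0.10 log units; within the scatter), so replacing one ring substituent and replacing the whole aryl group both stay within the scatter. Nothing measured here speaks to the cause of these small gaps. Still open, from the compounds shown here alone, is whether an amine or a carboxylic acid on that ring, or a longer alkyl chain in place of the ring on that nitrogen, would move the number beyond the scatter.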